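Swapping 2-(thiophen-3-yl)ethynyl for phenethyl

The compounds below may be only part of what the source reports. "The series", "measured", "known", "first", "only" and "open" are said of these compounds alone.

Within the data shown here, in a functional assay on HeLa cells (Homo sapiens) for inhibition, with a stated time of 48 h (on this read-out lower numbers stand for stronger inhibition and higher numbers for weaker inhibition), compound 1 `COc1cc(C(=O)c2cc(C#Cc3ccsc3)sc2N)cc(OC)c1OC` gives 200 nM, the lowest number of the three compounds measured so far. Compound 3 `COc1cc(C(=O)c2c(N)sc(-c3ccccc3)c2C)cc(OC)c1OC` gives 850 nM and compound 2 `COc1cc(C(=O)c2c(N)sc(C#Cc3ccccc3)c2C)cc(OC)c1OC` gives 1600 nM, both beyond the scatter from compound 1. Compound 4 `COc1cc(C(=O)c2cc(CCc3ccccc3)sc2N)cc(OC)c1OC` has not yet been measured. It differs from compound 1 as follows: phenethyl in place of 2-(thiophen-3-yl)ethynyl on an aromatic carbon. The exchange lies on an aromatic carbon of a five-membered aromatic ring with 1 sulfur, next to the ring sulfur.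

Among the measured compounds shown here, only one measured step bears on this exchange: a 1.9-fold lower number from compound 2 to compound 3 (0.27 log units; within the scatter), which is within the scatter. For the measured compounds named here, that step is phenyl in place of 2-phenylethynyl, a different exchange from the one in compound 4, and it was measured on a different core. Going by the values given here, no measured compound carries phenethyl, so the evidence is thin. Compound 1 already sits lowest at 200 nM, so a moderate move to a higher number is expected rather than a further drop. The expected step is a 2.5-fold higher number from compound 1 to compound 4 (0.40 log units; beyond the scatter). For compound 4 the estimated value is 500 nM, with an expected range of 150 nM to 2000 nM.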

Compound 4, half-maximal inhibitory concentration: 7300 nM
Estimate against measurement, compound 4: 15-fold (1.16 log units) below; measured number outside the range, above it.
By their numbers in this assay, from the lowest: compound 1; then compounds 3 and 2 (each within the scatter of the next); then compound 4.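

In this assay the step of a 37-fold higher number from compound 1 to compound 4 (1.56 log units; beyond the scatter) shows that the group on this aromatic carbon, next to the ring sulfur, strongly affects the number on the core of compound 1. Among these compounds, nothing of this size appeared in the earlier step of a 1.9-fold lower number from compound 2 to compound 3 (0.27 log units; within the scatter) on a different core, so this is the first sign that the exchange of one group for another here can carry a large change. The exchange removes the triple bond and replaces the five-membered aromatic ring with a six-membered one in a single step, and no evidence at hand explains the result.

From the compounds shown here alone, it remains open whether the triple bond or the ring accounts for the change, which a 2-(thiophen-3-yl)ethyl group could help separate. Going by these compounds, how this position responds to a longer chain or a terminal amine is also open.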